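The source may report more compounds than this note shows. Statements on the series, on what has been measured and on what is new or still open speak of the compounds shown alone.

Measured in a functional assay on HL-60 cells (Homo sapiens) for antiproliferative activity, with a stated time of 72 h; a lower number here means a stronger inhibitor of growth, a higher number a weaker inhibitor of growth:
- compound 1 `C=C(CC)C(=O)c1ccc(OCC(=O)O)cc1C`: > 60000 nM
- compound 2 `C=C(C)C(=O)c1ccc(OC(C)C(=O)O)cc1C`: > 60000 nM

In this assay compound 2 gives > 60000 nM, which is a limit and not a number. For the measured compounds named here, the series so far shows only (the limit of > 60000 nM in this assay, at which 2 of the 2 values shown sit).

Compound 3 `C=C(C)C(=O)c1ccc(OCC(=O)O)cc1C` carries hydrogen in place of methyl on a saturated chain carbon bound to a carbonyl carbon and an oxygen on an aromatic ring, 1-carboxyethoxy to carboxymethoxy: hydrogen in place of methyl on a saturated chain carbon bound to a carbonyl carbon and an oxygen on an aromatic ring. No measured step sizes this change. In this assay no step beyond the scatter is expected, in either direction. The expectation rests on compound 2, whose limit is > 60000 nM. The expected change is a step that the limit leaves unreadable from compound 2 to compound 3. Compound 3 is estimated at 70000 nM, within an expected range of 30000 nM to 120000 nM.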

Compound 3, concentration for 50% growth inhibition: > 60000 nM
Compound 3: a limit, no number (the forecaster's own chance of this, stated with the estimate: 75%); the middle value lies beyond the limit too.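

For the compounds shown here, compound 3, like compounds 1 and 2, gives only a limit, so no step among the three can be read: the limit of > 60000 nM in this assay, at which 3 of the 3 values shown sit. Left open is whether hydrogen in place of methyl changes anything at either place, since none of the three has a number.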